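The source may hold more compounds than are shown below. What is called first, only, known or untested is meant among the compounds shown, and "the series" means these compounds.

Compound 1 `O=C(Nc1ccc(Cl)cc1)C1CCCN(C(=O)c2cccc(-c3ccco3)c2)C1` and compound 2 `O=C(Nc1cccc([N+](=O)[O-])c1)C1CCCN(C(=O)c2cc(C(F)(F)F)cc(C(F)(F)F)c2)C1` share a core built from a piperidine-carboxamide bearing two amide groups, and both have been run in an ADME assay on PC-3 cells (Homo sapiens) for cytotoxicity, read by WST assay, tested at 100 uM; a higher number here means more inhibition at the concentration tested (going by the name of the read-out), a lower number less inhibition. In this assay compound 1 gives 0%, and compound 2 gives 9%; the gap between these two readings lies within the usual scatter, so the two compounds cannot be told apart on these numbers, and neither shows appreciable inhibition at the concentration tested.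

Compound 3 `O=C(Nc1ccc(Cl)cc1)C1CCCN(C(=O)c2cccc(-c3cccs3)c2)C1` has not yet been measured in this assay. Compared with compound 1 it carries one change: thiophen-2-yl in place of furan-2-yl on an aromatic carbon. Among the compounds with values here, no measured pair in this set shows what such an exchange does, so the expectation rests on the single reading of compound 1 alone. Since compound 1 gives 0%, a step from compound 1 to compound 3 of a number 5 percentage points higher from compound 1 to compound 3 (within the scatter) is expected, which is to say no change beyond the scatter. Compound 3 is therefore estimated at 5%, within a range from -10% to 20%.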

Compound 3, a percentage reported as inhibition, at one concentration (the size of the read-out at that concentration, not a potency) in the PC-3 assay: 4%
For compound 3 the middle estimate is 1 percentage points above the measured one; low and high end bracket the measured number.
By their numbers in the PC-3 assay, from the lowest: compounds 1, 3 and 2 (each within the scatter of the next).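

On an aromatic carbon meta to a large group, thiophen-2-yl in place of furan-2-yl gives, in the PC-3 assay, a number 4 percentage points higher from compound 1 to compound 3 (within the scatter), so this exchange leaves that reading where it was. The pair also gives a second reading that moves: in a physicochemical assay for solubility, measured as kinetic solubility (a lower number here means a less soluble compound, a higher number a more soluble compound), compound 1 gives 3.09 ug/mL and compound 3 gives 1.36 ug/mL. This makes the exchange a modest loss of solubility with no accompanying change in the cell reading: the measured solubility of compound 1, 3.09 ug/mL, and of compound 3, 1.36 ug/mL, a 2.3-fold lower number (0.36 log units; beyond the scatter)

From the compounds shown here alone, what an amine or a carboxylic acid at this same place would do to either reading stays open. A single pair also cannot say whether thiophen-2-yl in place of furan-2-yl would lower solubility in the same way with other groups elsewhere on the shared core.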